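The source may report more compounds than this note shows. Statements on the series, on what has been measured and on what is new or still open speak of the compounds shown alone.

an ADME assay on HepG2 cells (Homo sapiens) for cytotoxicity, read by MTT assay, with a stated time of 72 h (a higher number here means that more compound is tolerated, a lower number that less compound is tolerated), has so far been reported for two compounds that share a core and differ in the group on a triple-bonded carbon. Compound 1 `COc1cccc(C#Cc2cc(Cl)cn3c([N+](=O)[O-])c(CS(=O)(=O)c4ccccc4)nc23)c1` carries 3-methoxyphenyl there and gives > 3900 nM, which is a limit of the assay and not a number. Compound 2 `O=[N+]([O-])c1c(CS(=O)(=O)c2ccccc2)nc2c(C#Cc3cccs3)cc(Cl)cn12` carries thiophen-2-yl and gives > 3900 nM, which is also a limit, so compound 2 has no exact value of its own.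

Compound 3 `O=[N+]([O-])c1c(CS(=O)(=O)c2ccccc2)nc2c(C#Cc3ccc(CO)cc3)cc(Cl)cn12` differs from compound 2 at that same place: 4-(hydroxymethyl)phenyl in place of thiophen-2-yl on a triple-bonded carbon. In words, 4-(hydroxymethyl)phenyl stands in place of thiophen-2-yl on a triple-bonded carbon. Among the measured compounds shown here, the one measured step at this place is a step that the two limits leave unreadable from compound 1 to compound 2, so it gives no size to carry over. No change beyond the usual scatter is therefore expected in this assay, and another limit is the likeliest report, because of the limit of > 3900 nM in this assay, at which 2 of the 2 values shown sit. Read as an estimate, the expected step is a step that the limit leaves unreadable from compound 2 to compound 3. For compound 3 the estimated value is 6000 nM, with an expected range from 3000 nM to 20000 nM.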

Compound 3, half-maximal cytotoxic concentration: > 15600 nM
Compound 3: no number, only a limit (the forecaster's own chance of this, stated with the estimate: 70%); middle value at least 2.6-fold (0.41 log units) from the limit.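

In this assay compound 3 gives > 15600 nM, which is a limit of the assay and not a number. Among the compounds shown here, compound 1 and compound 2 also have only limits, and no step among compound 1, compound 2 and compound 3 can be read. Still open, as far as these compounds go, is whether the group on the triple-bonded carbon changes how much compound the cells tolerate.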